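Amide nitrogen substituent swap in a kinase inhibitor series

A few compounds are considered here, and "the series" means these few. Any claim that something is new, unique, unknown or untested is made for them only; others in the source may bear on it.

In an assay on lysate for inhibition of 6-phosphofructo-2-kinase/fructose-2,6-bisphosphatase 3 (Homo sapiens), with stated times of 0.5 min and 45 min (a lower number here means a stronger inhibitor, a higher number a weaker inhibitor), compound 1 `CN1CCC(NS(=O)(=O)c2ccccc2Nc2cc(-c3ccc4ccn(C)c4c3)c3nccnc3c2)C1` gives 3160 nM. Compound 2 `CN(C)C(=O)c1ccncc1Nc1cc(-c2ccc3ccn(C)c3c2)c2nccnc2c1` reaches only the limit of > 100000 nM in this assay. Compound 3 `Cn1ccc2ccc(-c3cc(Nc4cnccc4C(=O)NCc4cncnc4)cc4nccnc34)cc21` gives 49500 nM in this assay, and the step of an at least 2.0-fold lower number from compound 2 to compound 3 (0.30 log units; that floor lies within the scatter) starts from the limit of > 100000 nM in this assay, at which 1 of the 3 values shown sits. Of the two numbers shown, compound 3 holds the higher and compound 1 the lower, a gap beyond the scatter. Compound 4 `CN1CCC(NC(=O)c2ccncc2Nc2cc(-c3ccc4ccn(C)c4c3)c3nccnc3c2)CC1` differs from compound 3 by 1-methylpiperidin-4-yl in place of (pyrimidin-5-yl)methyl on an amide-type nitrogen. Within the data shown here, only the step from compound 2 to compound 3 touches the same amide nitrogen, and it is bounded by a limit, so the evidence is thin; compound 1, the one compound bearing a methylated piperidine, shows the lower number. Compound 4 is therefore expected at 20000 nM, a step of a 2.5-fold lower number from compound 3 to compound 4 (0.39 log units; beyond the scatter), with a range from 5000 nM to 80000 nM.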

Compound 4, half-maximal inhibitory concentration: 19500 nM
For compound 4 the middle estimate is 1.0-fold (0.01 log units) above the measured one; the range from low to high includes it.
By their numbers in this assay, from the lowest: compound 1; then compound 4; then compound 3. At a limit, above all of these: compound 2.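

Among these compounds, on the amide-type nitrogen, 1-methylpiperidin-4-yl in place of (pyrimidin-5-yl)methyl gives a 2.5-fold lower number from compound 3 to compound 4 (0.40 log units; beyond the scatter) in this assay, the first step at this position that joins two numbers rather than starting from a limit. Replacing dimethylamino on the carbonyl carbon with (1-methylpiperidin-4-yl)amino gives an at least 5.1-fold lower number from compound 2 to compound 4 (0.70 log units; beyond the scatter). That step is only a floor, as compound 2 stands at a limit: the limit of > 100000 nM in this assay, at which 1 of the 4 values shown sits.

From the compounds shown here alone, what piperidin-4-yl without its methyl, or an open 2-(dimethylamino)ethyl chain, would give on this nitrogen remains open.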